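A Sulfonyl Swap on the Weakest of Three Ureas

The compounds below may be only part of what the source reports. "The series", "measured", "known", "first", "only" and "open" are said of these compounds alone.

Three ureas have been measured in an assay on isolated protein for activation of Nicotinamide phosphoribosyltransferase (Homo sapiens); a higher number here means that more compound is needed for the effect, a lower number that less compound is needed. Compound 1 `O=C(NCc1ccncc1)Nc1ccc(S(=O)(=O)Nc2ccccc2)cc1` gives 410 nM and stands highest of the three numbers. Compound 2 `O=C(NCc1cn[nH]c1)Nc1ccc(S(=O)(=O)c2ccc(Cl)cc2)cc1` gives 23 nM, and compound 3 `O=C(NCc1cnco1)Nc1ccc(S(=O)(=O)c2cccc(OC(F)(F)F)c2)cc1` gives 70 nM; compound 1 is thus well beyond the scatter from both, with compound 3 nearer to it and compound 2 furthest away. Within the data shown here, compound 2 and compound 3 differ from compound 1 in several places at once, so no single step between measured compounds is available.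

Compound 4 `CCN(C1CCCC1)S(=O)(=O)c1ccc(NC(=O)NCc2ccncc2)cc1` is the untested analogue of compound 1, and it differs in one place: cyclopentyl(ethyl)amino in place of anilino on a sulfonyl sulfur. Because compound 1 sits at 410 nM while the other two lie far lower, there is room for movement in either direction, but nothing measured isolates this particular change. Compound 4 is expected to land near compound 1, with a step of a 1.6-fold lower number from compound 1 to compound 4 (0.21 log units; within the scatter) that may not exceed the scatter. The estimate for compound 4 in this assay is 250 nM, within 60 nM to 1000 nM.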

Compound 4, half-maximal effective concentration: 60 nM
The estimate for compound 4 lay 4.2-fold (0.62 log units) above the measured number; the range from low to high includes it.
By their numbers in this assay, from the lowest: compound 2; then compounds 4 and 3 (each within the scatter of the next); then compound 1.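

In this assay, among these compounds, cyclopentyl(ethyl)amino in place of anilino on a sulfonyl sulfur gives a 6.8-fold lower number from compound 1 to compound 4 (0.83 log units; beyond the scatter), the first single-place step and one beyond the scatter. It shows that this position does not need the six-membered aromatic ring of anilino or its hydrogen-bond donor, as the number falls when a five-membered non-aromatic ring enters and the donor leaves. Nothing measured here gives a reason for this step.

The compounds shown leave open which feature of the change goes with the lower number: the ethyl, the cyclopentyl ring or the loss of the donor. Cyclopentylamino, diethylamino and methyl(phenyl)amino on the same sulfur are absent from this set, so these features remain unseparated.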